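Notes on the step from compound 2 to compound 3

A few compounds are considered here, and "the series" means these few. Any claim that something is new, unique, unknown or untested is made for them only; others in the source may bear on it.

Measured in a functional assay on SiHa cells (Homo sapiens) for inhibition; on this read-out higher numbers stand for weaker inhibition and lower numbers for stronger inhibition:
- compound 1 `COc1cc(/C=C/C(=O)c2cccc(NC(=O)C(C)C)c2)ccc1O` gives 5.96 ug/mL
- compound 2 `COC(=O)C(=O)Nc1cccc(C(=O)/C=C/c2ccc(O)c(OC)c2)c1` gives 7.71 ug/mL

Compound 2 at 7.71 ug/mL lies within the scatter of compound 1 at 5.96 ug/mL, so the pair sets no order. Compound 3 `CCCC(=O)Nc1cccc(C(=O)/C=C/c2ccc(O)c(OC)c2)c1` is still unmeasured in this assay. Its change from compound 2 is propyl in place of methoxycarbonyl on a carbonyl carbon. Among the measured compounds shown here, one measured step bears on this: a 1.3-fold higher number from compound 1 to compound 2 (0.11 log units; within the scatter), methoxycarbonyl in place of isopropyl on a carbonyl carbon, and it stays within the scatter. Read in reverse, that single step gives no ground to expect a large change when propyl enters, though propyl itself is untested. The expected move is a 1.2-fold lower number from compound 2 to compound 3 (0.07 log units; within the scatter), which would be no step beyond the scatter. For compound 3 the estimated value is 6.5 ug/mL, with an expected range from 3.5 ug/mL to 12 ug/mL.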

Compound 3, half-maximal inhibitory concentration: 3.94 ug/mL
Compound 3: the middle estimate sits 1.6-fold (0.22 log units) above what was measured, and the stated range covers the measured number.
By their numbers in this assay, from the lowest: compounds 3, 1 and 2 (each within the scatter of the next).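

In this assay, propyl in place of methoxycarbonyl on a carbonyl carbon gives a 2.0-fold lower number from compound 2 to compound 3 (0.29 log units; within the scatter), so losing the hydrogen-bond acceptors counted on methoxycarbonyl produces no step beyond the scatter. Propyl in place of isopropyl at the same place, the first comparison of these two carbon groups, gives a 1.5-fold lower number from compound 1 to compound 3 (0.18 log units; within the scatter), so this pair does not separate the two groups either. With all three groups within the scatter of one another, the compounds set no order at this position, and nothing on hand offers an explanation for these numbers.

As far as these compounds go, whether any group at this carbonyl carbon can move the number beyond the scatter remains open. A longer chain such as hexyl, a terminal amine or a carboxylic acid would test this.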